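Two esters at the limit, and a third to come

The source may hold more compounds than are shown below. What is called first, only, known or untested is meant among the compounds shown, and "the series" means these compounds.

Two esters of one shared core have been measured in an assay for inhibition of hexokinase-2 (Homo sapiens), read by coupled enzyme assay, with a stated time of 10 min, in the presence of a further agent that is not named here; a higher number here means a weaker inhibitor, a lower number a stronger inhibitor. Compound 1 `C=C1CC[C@H]2[C@@](C)(CCC(=O)N[C@@]2(C)COC(=O)c2cccnc2)[C@@H]1/C=C/C1=CCOC1=O` carries a pyridin-3-yl group on the carbonyl carbon of its ester. In this assay compound 1 gives > 50000 nM, which is a limit of the assay rather than a number. Compound 2 `C=C1CC[C@H]2[C@@](C)(CCC(=O)N[C@@]2(C)COC(=O)c2ccccc2)[C@@H]1/C=C/C1=CCOC1=O` carries a phenyl group in the same place. In this assay compound 2 gives > 50000 nM, again a limit and not a number. The step that the two limits leave unreadable from compound 1 to compound 2 therefore cannot be read, since both ends sit at the limit of > 50000 nM in this assay, at which 2 of the 2 values shown sit. Compound 2 thus stands at the edge of what this assay can report, with no number of its own.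

Compound 3 `C=C1CC[C@H]2[C@@](C)(CCC(=O)N[C@@]2(C)COC(=O)[C@H](N)CC(C)C)[C@@H]1/C=C/C1=CCOC1=O` has not yet been measured. It differs from compound 2 in one place: 1-amino-3-methylbutyl in place of phenyl on a carbonyl carbon. Among the compounds with values here, no measured step here gives a readable size, so the only guide is that every value seen so far sits at the limit. The step that the limit leaves unreadable from compound 2 to compound 3 is therefore expected to stay unreadable, with compound 3 most likely at a limit as well. Compound 3 is estimated at 70000 nM, within a range from 20000 nM to 300000 nM.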

Compound 3, half-maximal inhibitory concentration: > 50000 nM
Compound 3: a limit, no number (the forecaster's own chance of this, stated with the estimate: 80%); the middle value lies beyond the limit too.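

In this assay compound 3 gives > 50000 nM, a limit of the assay and not a number. The steps among compound 1, compound 2 and compound 3 therefore cannot be read, since all three sit at the same limit: the limit of > 50000 nM in this assay, at which 3 of the 3 values shown sit.

As far as these compounds go, how pyridin-3-yl, phenyl and 1-amino-3-methylbutyl rank against one another on the carbonyl carbon stays open, as does the true number for each compound.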